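The compounds below may be only part of what the source reports. "The series", "measured", "known", "first", "only" and "open" are said of these compounds alone.

In a functional assay on A-375 cells (Homo sapiens) for activation, with a stated time of 3 days (on this read-out lower numbers stand for an effect already at smaller amounts and higher numbers for an effect only at larger amounts of compound), three compounds share one core and differ in a single aromatic ring. Compound 1 (`O=C(Nc1ccc(-c2ccncc2)cc1)C1CCCN(Cc2ccc(F)c(F)c2)C1`) gives 1180 nM, compound 2 (`O=C(Nc1ccc(-c2c[nH]cn2)cc1)C1CCCN(Cc2ccc(F)c(F)c2)C1`) gives 16000 nM, and compound 3 (`O=C(Nc1ccc(-c2ccco2)cc1)C1CCCN(Cc2ccc(F)c(F)c2)C1`), the furan-2-yl member, gives 2200 nM. Compound 3 is not separated from compound 1, since a 1.9-fold higher number from compound 1 to compound 3 (0.27 log units; within the scatter) stays within the scatter, but a 7.3-fold lower number from compound 2 to compound 3 (0.86 log units; beyond the scatter) lies beyond it. Compound 4 (`O=C(Nc1ccc(-c2ccc[nH]2)cc1)C1CCCN(Cc2ccc(F)c(F)c2)C1`) carries 1H-pyrrol-2-yl in place of furan-2-yl on an aromatic carbon, para to a large group: 1H-pyrrol-2-yl in place of furan-2-yl on an aromatic carbon. For the measured compounds named here, no measured step makes this exact exchange, so the evidence is indirect. Going by the values given here, compound 2, the only measured member with a ring named 1H, shows a 14-fold higher number from compound 1 to compound 2 (1.13 log units; beyond the scatter), a large step, whereas furan-2-yl in compound 3 barely moved the number. Compound 4 keeps the single hetero atom of furan-2-yl, so only part of that rise is expected in this assay. The expected change is small and upward, estimated as a 1.6-fold higher number from compound 3 to compound 4 (0.20 log units; within the scatter). For compound 4 the estimated value is 3500 nM, with an expected range from 1300 nM to 9500 nM.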

Compound 4, half-maximal effective concentration: 720 nM
Estimate against measurement, compound 4: 4.9-fold (0.69 log units) above; the whole stated range lies above it.
By their numbers in this assay, from the lowest: compounds 4, 1 and 3 (each within the scatter of the next, the first and the last beyond it); then compound 2.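

In this assay, replacing furan-2-yl with 1H-pyrrol-2-yl keeps a five-membered aromatic ring with 1 hetero atom and the same heavy-atom count, yet it produces a step beyond the scatter (a 3.1-fold lower number from compound 3 to compound 4 (0.49 log units; beyond the scatter)), so the identity of the hetero atom matters on this aromatic carbon, para to a large group. Compound 2 and compound 4 both carry a ring named 1H, but they lie far apart (a 22-fold lower number from compound 2 to compound 4 (1.35 log units; beyond the scatter)), so a 1H ring does not by itself bring a high number, while the pyridin-4-yl member remains unseparated (a 1.6-fold lower number from compound 1 to compound 4 (0.21 log units; within the scatter)). No measurement here accounts for the direction of these steps. The compounds shown leave open how a thiophen-2-yl or 1-methylpyrrol-2-yl ring would read here. The latter would test whether the hydrogen on the pyrrole nitrogen matters.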